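This account rests on a few compounds, and the source may have more. Where it says the series, first, only, none or still open, it means among the compounds named here.

Measured in a functional assay on PC-3 cells (Homo sapiens) for antiproliferative activity, read by MTT assay, with a stated time of 72 h; a higher number here means a weaker inhibitor, a lower number a stronger inhibitor:
- Compound 1 `C#CCSc1nc(Sc2nnnn2CCN(C)C)c(C#N)c(-c2ccc(Cl)cc2)n1`: 7170 nM
- Compound 2 `C#CCSc1nc(Sc2ccccn2)c(C#N)c(-c2cc(OC)c(OC)c(OC)c2)n1`: > 10000 nM
- Compound 3 `C#CCSc1nc(Sc2nccs2)c(C#N)c(-c2ccc(Br)cc2)n1`: 8530 nM

Compound 2 stands at > 10000 nM, which is a limit of the assay and not a number.

Compound 3 gives 8530 nM and compound 1 gives 7170 nM, two numbers that lie within the scatter of each other. Compound 3 therefore sits level with the only other numeric result in the set.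

Next in line is compound 4 `C#CCSc1nc(Sc2nccs2)c(C#N)c(-c2ccc(Cl)cc2)n1`, which differs from compound 3 in one place: chloro in place of bromo on an aromatic carbon. This puts chloro in place of bromo on an aromatic carbon of a six-membered aromatic ring of carbon only, para to a large group, so 4-bromophenyl becomes 4-chlorophenyl.

For the measured compounds named here, no measured pair isolates this change, so the expectation rests on the small size of the swap and on compound 1, which carries the 4-chlorophenyl group and gives 7170 nM. In this assay, no shift beyond the scatter is expected, in either direction. The expected 1.1-fold lower number from compound 3 to compound 4 (0.06 log units; within the scatter) is correspondingly small.

For compound 4 the estimated value is 7500 nM, with an expected range of 3500 nM to 10000 nM.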

Compound 4, half-maximal inhibitory concentration: 3620 nM
Compound 4: middle estimate off by 2.1-fold (0.32 log units), on the high side; measured number inside the range.
By their numbers in this assay, from the lowest: compounds 4, 1 and 3 (each within the scatter of the next, the first and the last beyond it). At a limit, above all of these: compound 2.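

In this assay, for the compounds shown here, this is the first pair to isolate the halogen at this position, on an aromatic carbon of a six-membered aromatic ring of carbon only, para to a large group. With the 1,3-thiazol-2-yl group held on the sulfur, 4-chlorophenyl in place of 4-bromophenyl gives a 2.4-fold lower number from compound 3 to compound 4 (0.37 log units; beyond the scatter), so the identity of the halogen here registers in the read-out, though only modestly. With 4-chlorophenyl held, 1,3-thiazol-2-yl in place of 1-(2-(dimethylamino)ethyl)-1H-tetrazol-5-yl on the sulfur gives a 2.0-fold lower number from compound 1 to compound 4 (0.30 log units; within the scatter), so in this pair the exchange of these two sulfur substituents is not resolved from repeat-measurement scatter, even though the two groups differ widely in structure.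

Going by these compounds, whether the halogen step holds with other groups on the sulfur remains open, as does the outcome with fluoro or an amine at the same position of the phenyl ring, or with a carboxylic acid on the sulfur substituent. Nothing in the measurements shown accounts for the halogen step.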